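This account rests on a few compounds, and the source may have more. Where it says the series, first, only, none or still open, it means among the compounds named here.

Measured compounds:
compound 1 `O=C(N/N=C/c1cccc(Cl)c1)c1cccnc1Nc1cccc(C(F)(F)F)c1` gives 76.7% in a functional assay on the whole organism (strain Wistar) for inhibition, with Rattus norvegicus as the target, read by paw edema, with a stated time of 1 h, at a dose of 10 mg/kg by the intraperitoneal route; a higher number here means more inhibition at the dose given (going by the name of the read-out), a lower number less inhibition;
compound 2 `O=C(N/N=C/c1ccc(O)c(O)c1)c1cccnc1Nc1cccc(C(F)(F)F)c1` gives 50.8%;
compound 3 `CN(C)c1ccc(/C=N/NC(=O)c2cccnc2Nc2cccc(C(F)(F)F)c2)cc1` gives 63.5%.

Compound 3 stands second highest of the three numbers, with compound 2 nearest and compound 1 furthest. Compound 4 `O=C(N/N=C/c1cccnc1)c1cccnc1Nc1cccc(C(F)(F)F)c1` is not yet measured. The change is pyridin-3-yl in place of 4-(dimethylamino)phenyl on a carbon with a double bond to nitrogen. Two measured steps act at the same place: a number 13.2 percentage points lower from compound 1 to compound 3 (beyond the scatter) and a number 12.7 percentage points higher from compound 2 to compound 3 (beyond the scatter), both modest. Among the compounds with values here, every change at this carbon with a double bond to nitrogen has so far moved the number by a modest amount, but no measured step introduces a pyridin-3-yl, so direction is uncertain; a modest step, or none beyond the scatter, is expected, a number 3.5 percentage points lower from compound 3 to compound 4 (within the scatter). Compound 4 is therefore expected to give 60%, between 45% and 75%.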

Compound 4, a percentage reported as inhibition, in the whole organism at one dose (the size of the read-out at that dose, not a potency): 76.1%
Beside the measured number, compound 4's estimate is 16.1 percentage points below it; the measured number lies above the stated range.
By their numbers in this assay, from the lowest: compound 2; then compound 3; then compounds 4 and 1 (each within the scatter of the next).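

Pyridin-3-yl on this carbon with a double bond to nitrogen brings a number 12.6 percentage points higher from compound 3 to compound 4 (beyond the scatter) and a number 25.3 percentage points higher from compound 2 to compound 4 (beyond the scatter) in this assay. With a number 0.6 percentage points lower from compound 1 to compound 4 (within the scatter) it cannot be told apart from 3-chlorophenyl, so a six-membered aromatic ring with 1 hetero atom now shares the top of these compounds with a ring of carbon only. No measurement at hand accounts for this result.

Going by these compounds, whether a carboxylic acid or a longer chain at this carbon would keep this level remains open. The trifluoromethyl group is common to all the compounds, so what it contributes is also unknown.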